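The compounds below may be only part of what the source reports. "The series", "measured", "known", "first", "only" and "open" are said of these compounds alone.

Measured in a functional assay on LOX IMVI cells (Homo sapiens) for cytotoxicity, read by MTT assay, with a stated time of 24 h; on this read-out lower numbers stand for stronger inhibition and higher numbers for weaker inhibition:
compound 1 `COc1cc(-c2nc(-c3ccccc3)[nH]c2-c2ccnc(NCCCNS(=O)(=O)c3ccc(Br)cc3)n2)ccc1Cl`: 23700 nM
compound 2 `COc1cc(-c2nc(-c3ccccc3)[nH]c2-c2ccnc(NCCCNS(=O)(=O)c3ccc(C(F)(F)F)cc3)n2)ccc1Cl`: 1780 nM
compound 3 `COc1cc(-c2nc(-c3ccccc3)[nH]c2-c2ccnc(NCCCNS(=O)(=O)c3ccc(C)cc3)n2)ccc1Cl`: 18600 nM

Compound 1 stands at the high end of these numbers: the step of a 1.3-fold lower number from compound 1 to compound 3 (0.11 log units; within the scatter) lies within the scatter, while the step of a 13-fold lower number from compound 1 to compound 2 (1.12 log units; beyond the scatter) is large. The step of a 10-fold higher number from compound 2 to compound 3 (1.02 log units; beyond the scatter) is also large. Compound 4 `O=S(=O)(NCCCNc1nccc(-c2[nH]c(-c3ccccc3)nc2-c2ccc(F)c(O)c2)n1)c1ccc(Br)cc1` keeps the bromo group of compound 1 but carries a different aryl group on the shared core: 4-fluoro-3-hydroxyphenyl in place of 4-chloro-3-methoxyphenyl on an aromatic carbon. Among the measured compounds shown here, none of the measured steps touches this place, as all three concern only the group exchanged for bromo, so they show only how far numbers can move. The step expected in this assay is therefore modest and downward, a 2.6-fold lower number from compound 1 to compound 4 (0.42 log units; beyond the scatter), though this is poorly constrained. For compound 4 the estimated value is 9000 nM, with an expected range of 2000 nM to 35000 nM.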

Compound 4, half-maximal inhibitory concentration: 5660 nM
Compound 4: middle estimate off by 1.6-fold (0.20 log units), on the high side; low and high end bracket the measured number.
By their numbers in this assay, from the lowest: compound 2; then compound 4; then compounds 3 and 1 (each within the scatter of the next).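

In this assay, among the compounds shown here, the exchange of 4-chloro-3-methoxyphenyl for 4-fluoro-3-hydroxyphenyl gives a 4.2-fold lower number from compound 1 to compound 4 (0.62 log units; beyond the scatter), so the number also responds at this aryl position on the shared core, which the earlier steps never touched. Nothing available accounts for this step. The compounds shown leave open whether the fluoro or the hydroxy part carries the step, as the two change together. Also open, on these data alone, are whether trifluoromethyl in place of bromo has the same effect alongside the new aryl group, and how an amine in place of the hydroxy would read.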